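Propyl in place of methoxy on the shared core

A few compounds are considered here, and "the series" means these few. Any claim that something is new, unique, unknown or untested is made for them only; others in the source may bear on it.

Measured so far in an ADME assay on the whole organism (plasma, strain Sprague-Dawley) for pharmacokinetics, with Rattus norvegicus as the target, at a dose of 10 mg/kg by the oral route (a higher number here means more compound in the circulation at the dose given, a lower number less compound in the circulation), for this series
compound 1 `COc1nc2cccnc2n1-c1ccc(Nc2ccc(C)cn2)cc1` gives 2510 ng.h/mL
compound 2 `COc1nc2cccnc2n1-c1ccc(Nc2nc3ccccc3s2)cc1` gives 4440 ng.h/mL

For the measured compounds named here, compound 1 has a single neighbour on these numbers, and the one measured step is a 1.8-fold higher number from compound 1 to compound 2 (0.25 log units; within the scatter) so the two values cannot be ordered. Going by the values given here, compound 3 `CCCc1nc2cccnc2n1-c1ccc(Nc2ccc(C)cn2)cc1` carries propyl in place of methoxy on an aromatic carbon as its one change. Among the compounds with values here, the measured step concerns a group on a nitrogen instead, so no measured step covers this place. In this assay no shift beyond the scatter is expected, and the estimated step is a 1.3-fold lower number from compound 1 to compound 3 (0.10 log units; within the scatter) with wide uncertainty. Compound 3 is estimated at 2000 ng.h/mL within a range of 600 ng.h/mL to 7000 ng.h/mL for now.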

Compound 3, area under the concentration-time curve: 1180 ng.h/mL
Beside the measured number, compound 3's estimate is 1.7-fold (0.23 log units) above it, within the range that was stated.
By their numbers in this assay, from the lowest: compound 3; then compounds 1 and 2 (each within the scatter of the next).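

In this assay the aromatic carbon between two ring nitrogen atoms on the shared core responds to its substituent: propyl in place of methoxy gives a 2.1-fold lower number from compound 1 to compound 3 (0.33 log units; beyond the scatter), a modest change. For the compounds shown here, this is the first step beyond the scatter, whereas the change on the nitrogen gave a 1.8-fold higher number from compound 1 to compound 2 (0.25 log units; within the scatter). No available evidence accounts for the shift.

From the compounds shown here alone, whether an amine or a longer chain at this carbon would track with methoxy or with propyl remains open. Also open, going by these compounds, is whether the change carries over when 1,3-benzothiazol-2-yl replaces 5-methylpyridin-2-yl.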